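A few compounds are considered here, and "the series" means these few. Any claim that something is new, unique, unknown or untested is made for them only; others in the source may bear on it.

Two compounds carry the same core with the same chain and differ only in the groups on the sugar. Compound 1 `CC[C@H](C)[C@H](NCCC1OCC(C)(C)CO1)C(=O)N[C@H]1[C@@H](OCc2ccccc2)O[C@H](COCc2ccccc2)[C@@H](OCc2ccccc2)[C@@H]1OCc1ccccc1` bears benzyl ethers, and in a functional assay on the whole organism (Ear, strain ICR) for inhibition, with Mus musculus as the target, with stated times of 30 min and 2 h, at a dose of 10 umol/kg by the oral route (on this read-out lower numbers stand for less inhibition and higher numbers for more inhibition at the one dose given (going by the name of the read-out)), compound 1 gives 81.6%. Compound 2 `CC[C@H](C)[C@H](NCCC1OCC(C)(C)CO1)C(=O)N[C@H]1[C@@H](OC(C)=O)O[C@H](COC(C)=O)[C@@H](OC(C)=O)[C@@H]1OC(C)=O` carries acetyl esters instead, and in this assay compound 2 gives 79.8%; the two values lie within the usual scatter of one another, so neither can be set apart from the other.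

Compound 3 `CC(=O)OC[C@H]1O[C@H](OC(C)=O)[C@H](NC(=O)[C@@H](NCCC2OCC(C)(C)CO2)C(C)C)[C@@H](OC(C)=O)[C@@H]1OC(C)=O` keeps the acetylated sugar of compound 2 and changes only the side chain: hydrogen in place of methyl on a saturated chain carbon, three bonds along the chain from an amine nitrogen and a carbonyl carbon. Going by the values given here, no step between measured compounds speaks to this change, and the two measured values give no sign that a small change of this kind moves the read-out. The expected step from compound 2 to compound 3 in this assay is therefore a number 2.8 percentage points lower from compound 2 to compound 3 (within the scatter), that is none beyond the scatter. Compound 3 is estimated at 77% in this assay, with a range from 60% to 90%.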

Compound 3, a percentage reported as inhibition, in the whole organism at one dose (the size of the read-out at that dose, not a potency): 70.6%
The estimate for compound 3 lay 6.4 percentage points above the measured number; the range from low to high includes it.
By their numbers in this assay, from the lowest: compounds 3, 2 and 1 (each within the scatter of the next, the first and the last beyond it).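

In this assay, going by these compounds alone, the step of a number 9.2 percentage points lower from compound 2 to compound 3 (within the scatter) gives the first reading at this position, on the acetylated sugar, and shows that the change from sec-butyl to isopropyl does not set the two compounds apart. Inhibition at the one dose given remains high without that methyl, as compound 3 gives 70.6% in this assay. Nothing measured here explains the size of this step.

On these data alone, whether the same position would accept a longer chain, a carboxylic acid or an amine in place of sec-butyl remains open. The compounds shown also leave open whether the change from sec-butyl to isopropyl would give a similar step on the sugar with benzyl ethers, and how it would read at other doses.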